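The source may hold more compounds than are shown below. What is called first, only, known or untested is meant among the compounds shown, and "the series" means these compounds.

Of the compounds shown here, three on the shared core have numbers so far in a functional assay on CCRF-CEM cells (Homo sapiens) for antiproliferative activity; a higher number here means a weaker inhibitor, a lower number a stronger inhibitor. Compound 2 (`COc1cc(C(=O)c2sc(-c3ccccc3)cc2N)cc(OC)c1OC`) carries a plain phenyl and gives 4.5 nM as the lowest number of the three. Compound 1 (`COc1cc(C(=O)c2sc(-c3ccc(Br)cc3)cc2N)cc(OC)c1OC`) gives 86 nM with 4-bromophenyl. Compound 3 (`COc1cc(C(=O)c2sc(-c3ccc(Cl)c(Cl)c3)cc2N)cc(OC)c1OC`) with 3,4-dichlorophenyl gives 290 nM and stands highest of the three.

The change to compound 4 (`COc1cc(C(=O)c2sc(-c3cccs3)cc2N)cc(OC)c1OC`) is thiophen-2-yl in place of 3,4-dichlorophenyl on an aromatic carbon on an aromatic carbon next to the ring sulfur. Within the data shown here, two measured steps bear on it most directly, both large: the one that adds the chlorines (a 64-fold higher number from compound 2 to compound 3 (1.81 log units; beyond the scatter)) and the one that removes the bromo (a 19-fold lower number from compound 1 to compound 2 (1.28 log units; beyond the scatter)). The gap between the two substituted compounds is modest (a 3.4-fold higher number from compound 1 to compound 3 (0.53 log units; beyond the scatter)). In these three compounds, each substituted aryl group gives a higher number than the plain phenyl. The thiophen-2-yl of compound 4 is likewise unsubstituted, which points towards compound 2 rather than compound 3. Among the measured compounds shown here, no five-membered ring has yet been measured at this place, so the match with phenyl is untested and the range stays wide.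

A large step to a lower number is therefore expected in this assay, and the expected step is a 24-fold lower number from compound 3 to compound 4 (1.38 log units; beyond the scatter) (estimated). For compound 4 the estimated value is 12 nM (expected range 3 nM to 60 nM).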

Compound 4, half-maximal inhibitory concentration: 9.4 nM
Compound 4: the middle estimate sits 1.3-fold (0.11 log units) above what was measured, within the range that was stated.
By their numbers in this assay, from the lowest: compound 2; then compound 4; then compound 1; then compound 3.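

In this assay a five-membered aromatic ring with one sulfur is accepted on this aromatic carbon next to the ring sulfur: a 31-fold lower number from compound 3 to compound 4 (1.49 log units; beyond the scatter) and a 9.1-fold lower number from compound 1 to compound 4 (0.96 log units; beyond the scatter) place thiophen-2-yl well on the low side of both halogenated aryl groups. Plain phenyl still gives the lowest number of the series, and a 2.1-fold higher number from compound 2 to compound 4 (0.32 log units; beyond the scatter) is a modest step beyond the scatter, much smaller than a 64-fold higher number from compound 2 to compound 3 (1.81 log units; beyond the scatter) and so showing that exchanging the ring costs far less here than adding the two chlorines. No measurement on hand explains this order of the four groups.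

The compounds shown leave open whether the low number extends to other five-membered rings, such as furan-2-yl or thiophen-3-yl, and whether a methyl or chloro group on the thiophen-2-yl ring would raise the number as the halogens on phenyl do in compound 1 and compound 3. Also open, going by these compounds, is whether the higher numbers of those two compounds are specific to halogens, or would also appear with a 4-methylphenyl or 4-methoxyphenyl group at this place.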